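The compounds below may be only part of what the source reports. "The series", "measured", "known", "first", "only" and "open" are said of these compounds alone.

Working notes on the series, read in a functional assay on XF498 cells (Homo sapiens) for antiproliferative activity, read by MTT assay, with a stated time of 96 h; on this read-out lower numbers stand for stronger inhibition and higher numbers for weaker inhibition. Compound 1 `O=C1NC(=O)C2(CSC3=C2C(=O)c2ncccc2C3=O)N1` gives 3120 nM. Going by the values given here, compound 2 `CCCCc1ccc(N2C(=O)NC3(CSC4=C3C(=O)c3ncccc3C4=O)C2=O)cc1` gives 950 nM, the lower of the two numbers so far. Compound 3 `CC(C)(C)c1ccc(N2C(=O)NC3(CSC4=C3C(=O)c3ncccc3C4=O)C2=O)cc1` is not yet measured. It differs from compound 2 as follows: tert-butyl in place of butyl on an aromatic carbon, para to a large group. Among the compounds with values here, only one measured step bears on this change, and only indirectly: a 3.3-fold lower number from compound 1 to compound 2 (0.52 log units; beyond the scatter), a modest step beyond the scatter, with 4-butylphenyl in place of hydrogen on an amide-type nitrogen in a ring. Within the data shown here, no measured pair compares butyl with tert-butyl, so the direction stays open and no step beyond the scatter is expected. The expected step is a 1.1-fold lower number from compound 2 to compound 3 (0.02 log units; within the scatter), an estimate that stays within the scatter. For compound 3 the estimated value is 900 nM, with an expected range of 400 nM to 2000 nM.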

Compound 3, half-maximal inhibitory concentration: 850 nM
Estimate against measurement, compound 3: 1.1-fold (0.02 log units) above, and the stated range covers the measured number.
By their numbers in this assay, from the lowest: compounds 3 and 2 (each within the scatter of the next); then compound 1.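

In this assay, the shape of the four-carbon group on an aromatic carbon, para to a large group, does not separate the two compounds: a 1.1-fold lower number from compound 2 to compound 3 (0.05 log units; within the scatter). The step from the amide hydrogen of compound 1 survives this swap, with a 3.7-fold lower number from compound 1 to compound 3 (0.56 log units; beyond the scatter), so it now stands for two different 4-alkylphenyl groups rather than for 4-butylphenyl alone, and neither compound goes against it. Nothing at hand gives a reason why butyl and tert-butyl read alike here.

Open, on these data alone, is how much of the step from compound 1 belongs to the phenyl ring and how much to the alkyl group on it, which an unsubstituted phenyl would address. Also open, as far as these compounds go, is whether this tolerance extends beyond butyl and tert-butyl to a methyl, a longer chain, an amine or a carboxylic acid at the same place.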